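This account rests on a few compounds, and the source may have more. Where it says the series, first, only, none or still open, it means among the compounds named here.

Compounds tested in an ADME assay on Vero cells (Chlorocebus sabaeus) for cytotoxicity, with a stated time of 72 h; a higher number here means a weaker inhibitor, a lower number a stronger inhibitor:

- Compound 1 `O=C(CCN1CCN(c2ccc([N+](=O)[O-])cc2)CC1)c1csc2ccccc12`: 1710000 nM
- Compound 2 `O=C(CCN1CCN(c2ccc([N+](=O)[O-])cc2)CC1)c1csc2ccc(F)cc12`: 554000 nM
- Compound 3 `O=C(CCN1CCN(c2ccc([N+](=O)[O-])cc2C(F)(F)F)CC1)c1csc2ccccc12`: not yet measured

In this assay, going by the values given here, compound 1 has the higher of the two numbers so far, at 1710000 nM. Compound 3 differs from it by one change: trifluoromethyl in place of hydrogen on an aromatic carbon. This is trifluoromethyl in place of hydrogen on an aromatic carbon, ortho to a large group and meta to a nitro group.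

Among the compounds with values here, only one measured step bears on this: a 3.1-fold lower number from compound 1 to compound 2 (0.49 log units; beyond the scatter), with fluoro in place of hydrogen on an aromatic carbon. That step involves a different group in a different place, so it is a thin guide. A modest move towards a lower number is still expected in this assay. The expected step is a 2.3-fold lower number from compound 1 to compound 3 (0.36 log units; beyond the scatter). For compound 3 the estimated value is 750000 nM, with an expected range from 250000 nM to 2000000 nM.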

Compound 3, half-maximal inhibitory concentration: 2850000 nM
Compound 3: the middle estimate sits 3.8-fold (0.58 log units) below what was measured, and the stated range ends below it.
By their numbers in this assay, from the lowest: compound 2; then compounds 1 and 3 (each within the scatter of the next).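

In this assay, putting trifluoromethyl in place of hydrogen on an aromatic carbon, ortho to a large group and meta to a nitro group, gives a 1.7-fold higher number from compound 1 to compound 3 (0.22 log units; within the scatter). This adds four heavy atoms at this position, yet the measured number stays within the usual scatter of the parent compound. The earlier step, a 3.1-fold lower number from compound 1 to compound 2 (0.49 log units; beyond the scatter), involves a different group in a different place, so it does not describe what happens at this position, and no measurement is available here that explains the new result.

The compounds shown leave open whether a methyl group, an amine or a carboxylic acid at this position would also stay within the scatter. They also leave open how fluoro alone would behave at this position.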